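This account rests on a few compounds, and the source may have more. Where it says the series, first, only, none or still open, it means among the compounds named here.

Measured so far:
compound 1, `O=C(N[C@@H](CO)C(=O)NO)c1ccc(C#Cc2ccccc2)cc1`, 2
compound 2, `O=C(NC1(C(=O)NO)CCCCC1)c1ccc(C#Cc2ccccc2)cc1`, > 3
compound 3, `O=C(NC1(C(=O)NO)CCS(=O)(=O)CC1)c1ccc(C#Cc2ccccc2)cc1`, 3

In a physicochemical assay for lipophilicity (a lower number here means a more polar compound, a higher number a more lipophilic compound), compound 1 gives 2, the lowest of the two numbers shown. Compound 3 gives 3, a higher number, and the gap between compound 1 and compound 3 lies beyond the scatter. Compound 2 gives > 3, which is a limit of this assay and not a number. The evidence on that point is the limit of > 3 in this assay, at which 1 of the 3 values shown sits. Within the data shown here, no two of these three compounds differ in only one place, so no measured step is available.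

Compound 4, `COCCNC(=O)C[C@H](NC(=O)c1ccc(C#Cc2ccccc2)cc1)C(=O)NO`, is yet to be measured in this assay. Its difference from compound 1 is (2-methoxyethyl)carbamoyl in place of hydroxy on a saturated chain carbon, two bonds along the chain from an amide-type nitrogen and a carbonyl carbon. Among the measured compounds shown here, with no measured step of the same kind in the set, the expectation rests on the counted change alone: a small rise, of about the size of the scatter, is expected, a number 0.30 log units higher from compound 1 to compound 4 (within the scatter). Compound 4 is accordingly estimated at 2.3, with a range from 1.7 to 2.9. A limit rather than a number is considered unlikely for compound 4.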

Compound 4, distribution coefficient: 2
For compound 4 the middle estimate is 0.30 log units above the measured one; the range from low to high includes it.
By their numbers in this assay, from the lowest: compounds 1 and 4 (each within the scatter of the next); then compound 3.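

In this assay, among these compounds, the change to (2-methoxyethyl)carbamoyl in place of hydroxy on a saturated chain carbon, two bonds along the chain from an amide-type nitrogen and a carbonyl carbon, gives no change at the digits printed from compound 1 to compound 4 (within the scatter) and is the first step that can be read. The earlier compounds shown here offered no pair differing in one place, so this position had no measured step; it now has one, and it shows that a group far larger by its heavy-atom count, with no ring and no net charge like the hydroxy it replaces, can stand here with the read-out staying within the scatter. Nothing measured in the compounds shown gives a reason for this result.

This is one step with one neutral group, so it does not tell whether the same reading would hold for other groups at this position. As far as these compounds go, a carboxylic acid or an amine on the same chain, or a longer chain ending in methoxy, remains open, as does whether the result carries over to the cores of compound 2 and compound 3.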